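A few compounds are considered here, and "the series" means these few. Any claim that something is new, unique, unknown or untested is made for them only; others in the source may bear on it.

Compound 2 `CC(C)(N)CC(=O)N[C@@H]1CCc2ccccc2N(Cc2ccc(-c3ccccc3-c3nc[nH]n3)cc2)C1=O` stands at the lowest number of the three measured compounds in a functional assay (Pituitary gland cell) with Rattus norvegicus as the target (on this read-out higher numbers stand for an effect only at larger amounts of compound and lower numbers for an effect already at smaller amounts), where compound 2 gives 90 nM. Compound 1 `Cc1noc(-c2ccccc2-c2ccc(CN3C(=O)[C@H](NC(=O)CC(C)(C)N)CCc4ccccc43)cc2)n1` gives 1050 nM in this assay, and compound 3 `COc1nsnc1-c1ccccc1-c1ccc(CN2C(=O)[C@H](NC(=O)CC(C)(C)N)CCc3ccccc32)cc1` gives 1800 nM. Compound 4 `CC(C)(N)CC(=O)N[C@@H]1CCc2ccccc2N(Cc2ccc(-c3sccc3-c3nn[nH]n3)cc2)C1=O` carries the change (3-(2H-tetrazol-5-yl)thiophen-2-yl in place of 2-(1H-1,2,4-triazol-3-yl)phenyl on an aromatic carbon). Among the compounds with values here, two measured steps bear on it: the step of a 12-fold lower number from compound 1 to compound 2 (1.07 log units; beyond the scatter) and the step of a 20-fold higher number from compound 2 to compound 3 (1.30 log units; beyond the scatter), both showing that the identity of the five-membered aromatic ring with three hetero atoms alters the read-out of this assay by a large amount. Within the data shown here, compound 4 keeps a ring bearing one hydrogen-bond donor, as compound 2 does, but it also exchanges the six-membered aromatic ring of carbon only for a five-membered aromatic ring with one hetero atom, a change for which no measured step exists. For compound 4 a modest rise in the number is therefore expected, a 2.2-fold higher number from compound 2 to compound 4 (0.35 log units; beyond the scatter), with a wide range. Compound 4 is estimated to give about 200 nM in this assay, between 50 nM and 900 nM.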

Compound 4, half-maximal effective concentration: 140 nM
Beside the measured number, compound 4's estimate is 1.4-fold (0.15 log units) above it; the measured number falls inside the stated range.
By their numbers in this assay, from the lowest: compounds 2 and 4 (each within the scatter of the next); then compounds 1 and 3 (each within the scatter of the next).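

In this assay, 3-(2H-tetrazol-5-yl)thiophen-2-yl in place of 2-(1H-1,2,4-triazol-3-yl)phenyl gives a 1.6-fold higher number from compound 2 to compound 4 (0.19 log units; within the scatter), so the two groups cannot be told apart here even though both of their rings differ. The earlier compounds shown here varied only the five-membered ring with 3 hetero atoms on an unchanged six-membered aromatic ring of carbon only, whereas this result shows that the latter ring can be exchanged for the thiophen ring of the 3-(2H-tetrazol-5-yl)thiophen-2-yl group without a change beyond the scatter, and the new group also stays clearly apart from the 2-(3-methyl-1,2,4-oxadiazol-5-yl)phenyl group, with a 7.5-fold lower number from compound 1 to compound 4 (0.88 log units; beyond the scatter). No evidence is available on what lies behind these numbers.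

From the compounds shown here alone, the two rings change together in compound 4, so what each contributes alone stays open. Also open, going by these compounds, is how a carboxylic acid in place of the tetrazole would read in this assay.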